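The source may report more compounds than this note shows. Statements on the series, on what has been measured and on what is new or still open speak of the compounds shown alone.

Measured compounds:
compound 1, `O=C1NCc2c1c1c(c3c2c2ccccc2n3CCO)CCc2cc(OC3CCCCC3)ccc2-1` — 35%
compound 2, `N#CCOc1ccc2c(c1)CCc1c-2c2c(c3c4ccccc4n(CCO)c13)CNC2=O` — 30%
compound 3, `COCCOc1ccc2c(c1)CCc1c-2c2c(c3c4ccccc4n(CCO)c13)CNC2=O` — 52%

In an assay on isolated protein for inhibition of mitogen-activated protein kinase kinase kinase 9 (Homo sapiens), tested at 1 uM (on this read-out higher numbers stand for more inhibition at the one concentration tested (going by the name of the read-out) and lower numbers for less inhibition), compound 3 gives the highest of the three numbers. Its nearest neighbour is compound 1, with a step of a number 17 percentage points higher from compound 1 to compound 3 (beyond the scatter) on swapping the groups on the oxygen, and the furthest is compound 2, with a number 22 percentage points higher from compound 2 to compound 3 (beyond the scatter). Compound 1 and compound 2 sit within the scatter of each other, a number 5 percentage points lower from compound 1 to compound 2 (within the scatter).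

The next compound, compound 4, `N#CCCCOc1ccc2c(c1)CCc1c-2c2c(c3c4ccccc4n(CCO)c13)CNC2=O`, differs from compound 3 in one place: cyanomethyl in place of methoxy on a saturated chain carbon, two bonds along the chain from an oxygen on an aromatic ring. Going by the values given here, the step that bears most on it is the one from compound 2 to compound 3, where methoxymethyl in place of cyano on the chain carbon raised the number by a modest amount. Among the compounds with values here, compound 4 brings the nitrile back, though on a longer chain, so a modest drop in this assay is expected, a number 14 percentage points lower from compound 3 to compound 4 (beyond the scatter), with the caution that no measured compound carries this longer chain. For compound 4 the estimate is 38%, within 20% to 58%.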

Compound 4, a percentage reported as inhibition, at one concentration (the size of the read-out at that concentration, not a potency): 58%
The estimate for compound 4 lay 20 percentage points below the measured number; low and high end bracket the measured number.
By their numbers in this assay, from the lowest: compounds 2 and 1 (each within the scatter of the next); then compounds 3 and 4 (each within the scatter of the next).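

In this assay, a nitrile at the end of the chain is compatible with the higher numbers in this series: with 3-cyanopropyl in place of 2-methoxyethyl, the result is a number 6 percentage points higher from compound 3 to compound 4 (within the scatter), so these two chains cannot be told apart here. The low number seen with the shorter cyanomethyl group therefore does not carry over to the longer nitrile chain, which gives a number 28 percentage points higher from compound 2 to compound 4 (beyond the scatter), while 3-cyanopropyl in place of cyclohexyl gives a number 23 percentage points higher from compound 1 to compound 4 (beyond the scatter). Nothing in the data explains these steps.

The compounds shown leave open whether a still longer nitrile chain would keep the number at this level or whether chain length alone accounts for the gain. They also leave open how an amine or a carboxylic acid at the end of the chain would read, and since each number comes from one concentration, they give no potency.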